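Swapping a Benzoyl for a Pyridinyloxy Group

The source may report more compounds than this note shows. Statements on the series, on what has been measured and on what is new or still open speak of the compounds shown alone.

Three compounds sharing one core were tested in an ADME assay on PC-3 cells (Homo sapiens) for cytotoxicity, read by WST assay, tested at 100 uM; on this read-out lower numbers stand for less inhibition and higher numbers for more inhibition at the one concentration tested (going by the name of the read-out). Compound 1 `O=C(Nc1cccc(Oc2ccccc2)c1)C1CCCN(C(=O)c2cc(C(F)(F)F)cc(C(F)(F)F)c2)C1` gives 1% in this assay. Compound 2 `CC(=O)c1cccc(NC(=O)C2CCCN(C(=O)c3cc(C(F)(F)F)cc(C(F)(F)F)c3)C2)c1` gives 0%, and compound 3 `O=C(c1ccccc1)c1cccc(NC(=O)C2CCCN(C(=O)c3cc(C(F)(F)F)cc(C(F)(F)F)c3)C2)c1` gives 0%. Compound 3 stands level with compound 2 at the digits printed, and together they are the lowest of the three numbers, although the gap is only a number 1 percentage points lower from compound 1 to compound 3 (within the scatter), which means all three sit in one cluster.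

Compound 4 `O=C(Nc1cccc(Oc2nccc(C(F)(F)F)c2Cl)c1)C1CCCN(C(=O)c2cc(C(F)(F)F)cc(C(F)(F)F)c2)C1` differs from compound 3 in one place: (3-chloro-4-(trifluoromethyl)pyridin-2-yl)oxy in place of benzoyl on an aromatic carbon. The step most closely related is the one in which benzoyl replaced phenoxy, because a number 1 percentage points lower from compound 1 to compound 3 (within the scatter) was within the scatter; the reverse direction, an aryloxy group in place of benzoyl, is what compound 4 carries, with a chlorinated, trifluoromethyl-bearing pyridine in place of the plain phenyl of compound 1. The other steps, a number 1 percentage points lower from compound 1 to compound 2 (within the scatter) and no change at the digits printed from compound 2 to compound 3 (within the scatter), were likewise within the scatter. No step among these compounds moved the read-out beyond the scatter, so the expected step is a number 1 percentage points higher from compound 3 to compound 4 (within the scatter), meaning no change beyond the scatter. Compound 4 is therefore estimated at 1%, with a range from -5% to 10%.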

Compound 4, a percentage reported as inhibition, at one concentration (the size of the read-out at that concentration, not a potency): 0%
Estimate against measurement, compound 4: 1 percentage points above, and the stated range covers the measured number.
By their numbers in this assay, from the lowest: compounds 2, 3, 4 and 1 (each within the scatter of the next).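

In this assay, putting (3-chloro-4-(trifluoromethyl)pyridin-2-yl)oxy in place of benzoyl on this aromatic carbon, meta to a large group, brings in a ring with a hetero atom along with chlorine and fluorine, yet the read-out shows no change at the digits printed from compound 3 to compound 4 (within the scatter) as its result. Set against the acetyl group the picture is the same (no change at the digits printed from compound 2 to compound 4 (within the scatter)), and changing only the ring on the oxygen, with the substituted pyridine in place of phenyl, gives a number 1 percentage points lower from compound 1 to compound 4 (within the scatter) as its result, so this larger, more heavily substituted group joins acetyl, benzoyl and phenoxy in one cluster. Nothing measured here explains why the read-out stays flat across these groups.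

The compounds shown leave open whether any group at this position can move the read-out at all, for instance a primary amine, a carboxylic acid or a longer alkyl chain on this aromatic carbon. They also leave open whether the flat picture depends on the rest of the shared core, which stays the same in all four compounds.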